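Thiourea series: cytotoxicity notes, compound 3 to compound 4

The source may hold more compounds than are shown below. What is called first, only, known or untested is meant among the compounds shown, and "the series" means these compounds.

Compound 1, `NC(=S)N1CCCc2c(OCCCCCOc3cccc4ccccc34)cccc21`: > 50000 nM
Compound 2, `O=C(NC(=S)N1CCc2ccc(OCc3ccccc3)cc21)c1ccccc1`: 43800 nM
Compound 3, `O=C(NC(=S)N1CCc2c(OCCCCCOc3ccc(Cl)cc3)cccc21)c1ccc(Br)cc1`: 29100 nM

In an ADME assay on Huh-7 cells (Homo sapiens) for cytotoxicity (a higher number here means that more compound is tolerated, a lower number that less compound is tolerated), the value of compound 1 is a limit of the assay, not a number (the limit of > 50000 nM in this assay, at which 1 of the 3 values shown sits). Compound 2 and compound 3 both give numbers; compound 3 is numerically the lower of the two, but its gap to compound 2 is within the scatter, so the pair cannot be told apart. Compound 4, `O=C(NC(=S)N1CCc2c(OCCCCCOc3ccc(Cl)cc3)cccc21)c1cc2ccccc2s1`, differs from compound 3 in one place: 1-benzothiophen-2-yl in place of 4-bromophenyl on a carbonyl carbon. Among the compounds with values here, no measured pair shows a change of this kind, so its size is open. In this assay a step of a 1.3-fold lower number from compound 3 to compound 4 (0.12 log units; within the scatter) is expected, downward but not clearly beyond the scatter. Compound 4 is estimated at 22000 nM, in the range 9000 nM to 50000 nM.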

Compound 4, half-maximal cytotoxic concentration: > 50000 nM
Compound 4: only a limit was reported; the forecaster's own chance of this, stated with the estimate: 20%; at least 2.2-fold (0.35 log units) between middle value and limit.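

On a carbonyl carbon, 1-benzothiophen-2-yl in place of 4-bromophenyl gives in this assay an at least 1.7-fold higher number from compound 3 to compound 4 (0.23 log units; that floor lies within the scatter), the only reading of a change at this position among the compounds shown. The result for compound 4 is a limit of the assay, not a number, as is the result for compound 1: the limit of > 50000 nM in this assay, at which 2 of the 4 values shown sit. Within the data shown here, the step therefore has only a floor, and this exchange shows no sign of less compound being tolerated.

Going by these compounds, how far the step reaches stays open. Also open, on these data alone, is whether an amine or a carboxylic acid in place of 4-bromophenyl on a carbonyl carbon would shift the number.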